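Swapping an Aryl Arm for an Ester on a Shared Core

A few compounds are considered here, and "the series" means these few. Any claim that something is new, unique, unknown or untested is made for them only; others in the source may bear on it.

Compound 1, `CCc1ccc(-c2ccc(NC3=CC(=O)c4ncncc4C3=O)cc2)cc1`: 3100 nM
Compound 2, `Cc1ccc(-c2ccc(NC3=CC(=O)c4ncncc4C3=O)cc2F)cc1`: 5000 nM
Compound 3, `COc1cc(NC2=CC(=O)c3ncncc3C2=O)cc(OC)c1OC`: 1600 nM

All three were tested in a functional assay on BXPC-3 cells (Homo sapiens) for cytotoxicity, read by MTT assay, with a stated time of 72 h; a lower number here means a stronger inhibitor, a higher number a weaker inhibitor. Compound 1 stands second highest of the three numbers; its nearest neighbour is compound 2 and its furthest is compound 3, yet both gaps lie within the scatter, so no order can be read among them. Compound 4, `COC(=O)c1ccc(NC2=CC(=O)c3ncncc3C2=O)cc1`, has not yet been measured. It differs from compound 1 in one place: methoxycarbonyl in place of 4-ethylphenyl on an aromatic carbon. For the measured compounds named here, no measured pair shows a change of this kind, so there is no step to lean on. Compound 4 is expected to give a somewhat higher number than compound 1, though a step no larger than the scatter would not surprise. The expected step is a 1.6-fold higher number from compound 1 to compound 4 (0.21 log units; within the scatter). Compound 4 is estimated at 5000 nM, with a range from 1500 nM to 16000 nM.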

Compound 4, half-maximal inhibitory concentration: 5800 nM
Compound 4: the middle estimate sits 1.2-fold (0.06 log units) below what was measured; low and high end bracket the measured number.
By their numbers in this assay, from the lowest: compounds 3, 1, 2 and 4 (each within the scatter of the next, the first and the last beyond it).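

Replacing 4-ethylphenyl with methoxycarbonyl para to a large group gives a 1.9-fold higher number from compound 1 to compound 4 (0.27 log units; within the scatter) in this assay on the shared core. At this place, an arm with an aromatic ring and a smaller one with no ring and with hydrogen-bond acceptors therefore give numbers that cannot be told apart. No measurement at hand explains this result.

As far as these compounds go, whether a carboxylic acid, an amide or a longer alkyl chain here would move the number beyond the scatter remains open. So does the effect of a bare hydrogen in this place.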